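Thiophene in place of pyridine on the shared core

The source may report more compounds than this note shows. Statements on the series, on what has been measured and on what is new or still open speak of the compounds shown alone.

Measured so far:
compound 1 `Oc1ccc(-c2cc(-c3cccs3)nc(-c3ccccc3Cl)c2)cc1`: 4190 nM
compound 2 `Oc1cccc(-c2cc(-c3cccc(Cl)c3)nc(-c3cccs3)c2)c1`: 2650 nM
compound 3 `Oc1ccc(-c2cc(-c3cccnc3)nc(-c3cccc(Cl)c3)c2)cc1`: 22900 nM

In a functional assay on DU-145 cells (Homo sapiens) for cytotoxicity, read by CCK-8 assay and cell counting, with a stated time of 2 days (on this read-out higher numbers stand for weaker inhibition and lower numbers for stronger inhibition), compound 3 stands highest of the three numbers, beyond the scatter from both compound 1 and compound 2. Compound 4 `Oc1ccc(-c2cc(-c3cccc(Cl)c3)nc(-c3cccs3)c2)cc1` has not been measured. It differs from compound 3 in one place: thiophen-2-yl in place of pyridin-3-yl on an aromatic carbon. For the measured compounds named here, no measured pair shows this change alone, so its size is unknown. Both compounds that carry thiophen-2-yl sit far lower than compound 3, because compound 1 gives 4190 nM and compound 2 gives 2650 nM. Compound 4 is therefore expected to come down toward those two, with an estimated step of a 5.7-fold lower number from compound 3 to compound 4 (0.76 log units; beyond the scatter). Compound 4 is estimated at 4000 nM, within 1500 nM to 12000 nM.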

Compound 4, half-maximal inhibitory concentration: 5740 nM
Compound 4: the middle estimate sits 1.4-fold (0.16 log units) below what was measured; the measured number falls inside the stated range.
By their numbers in this assay, from the lowest: compounds 2, 1 and 4 (each within the scatter of the next, the first and the last beyond it); then compound 3.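

In this assay thiophen-2-yl in place of pyridin-3-yl, on the aromatic carbon next to the ring nitrogen, now has a measured size (a 4.0-fold lower number from compound 3 to compound 4 (0.60 log units; beyond the scatter)). The hydroxyl position also counts on this thiophene-bearing core, with 4-hydroxyphenyl in place of 3-hydroxyphenyl giving a modest step (a 2.2-fold higher number from compound 2 to compound 4 (0.34 log units; beyond the scatter)). By contrast, 3-chlorophenyl in place of 2-chlorophenyl does not separate the pair (a 1.4-fold higher number from compound 1 to compound 4 (0.14 log units; within the scatter)).

No measurement shown accounts for these steps. On these data alone, whether furan-2-yl or phenyl would match thiophen-2-yl here remains open, as does the outcome of methoxy in place of the hydroxyl.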